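This account rests on a few compounds, and the source may have more. Where it says the series, first, only, none or still open, it means among the compounds named here.

Measured so far:
compound 1 `c1cncc(N2C[C@H]3CCNC[C@H]32)c1` – 1400 nM
compound 2 `Clc1ccc(N2C[C@@H]3CCNC[C@@H]32)cn1` – 37.4 nM
compound 3 `Clc1ccc(N2C[C@H]3CCNC[C@H]32)cn1` – 216 nM

All three were tested in a functional assay on HEK293 cells for agonist activity at Neuronal acetylcholine receptor; alpha4/beta2 (Homo sapiens), read by FLIPR; on this read-out higher numbers stand for an effect only at larger amounts of compound and lower numbers for an effect already at smaller amounts. Compound 3 stands second highest of the three numbers: compound 2 sits below it, and compound 1 above it. Two steps reach compound 3. The first, a 6.5-fold lower number from compound 1 to compound 3 (0.81 log units; beyond the scatter), adds a chloro group to the ring. The second, a 5.8-fold higher number from compound 2 to compound 3 (0.76 log units; beyond the scatter), is a change of configuration alone, as the fact that compounds 2 and 3 differ only in the configuration as drawn shows.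

Compound 4 `Cc1cc(N2C[C@H]3CCNC[C@H]32)cnc1Cl` differs from compound 3 by methyl in place of hydrogen on an aromatic carbon. Going by the values given here, neither measured step adds a methyl, so neither bears directly on this change; the chloro step shows only that the ring tolerates a small substituent. A small step in either direction is therefore expected, and compound 4 is estimated at 350 nM (range 80 nM to 1500 nM), meaning a 1.6-fold higher number from compound 3 to compound 4 (0.21 log units; within the scatter).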

Compound 4, half-maximal effective concentration: 134 nM
Beside the measured number, compound 4's estimate is 2.6-fold (0.42 log units) above it, within the range that was stated.
By their numbers in this assay, from the lowest: compound 2; then compounds 4 and 3 (each within the scatter of the next); then compound 1.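

In this assay the step for methyl in place of hydrogen is a 1.6-fold lower number from compound 3 to compound 4 (0.21 log units; within the scatter) and so shows that this aromatic carbon, ortho to the chloro group and two atoms from the ring nitrogen, accepts a carbon group with no difference that can be told from the scatter. The chloro step concerned another change and could not show this. Nothing measured here gives a reason for this result. Going by these compounds, whether an ethyl chain, a methoxy group or an amine on this carbon would give a similar number stays open. So does whether methyl would do the same on compound 2, the mirror image of compound 3.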